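This account rests on a few compounds, and the source may have more. Where it says the series, first, only, none or still open, it means among the compounds named here.

Measured so far in an ADME assay on L6 cells (Rattus norvegicus) for cytotoxicity, read by resazurin assay, with a stated time of 72 h; on this read-out lower numbers stand for stronger inhibition and higher numbers for weaker inhibition:
- compound 1 `Cc1ccc(C(O)(c2ccc(Cl)cc2)c2cccnc2)cc1` gives 61000 nM
- compound 2 `COc1ccc(C(O)(c2ccc(Cl)cc2)c2cccnc2)cc1` gives 68100 nM

Going by the values given here, compound 2 stands level with compound 1, the only other measured compound, since the two values lie within the scatter of each other. Compound 3 `CC(C)Oc1ccc(C(O)(c2ccc(Cl)cc2)c2cccnc2)cc1` keeps the shared core and departs from compound 2 in one place: isopropyl in place of methyl on an oxygen on an aromatic ring (isopropyl in place of methyl on an oxygen on an aromatic ring, or methoxy to isopropoxy).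

Among the compounds with values here, only one measured step bears on this change, and only indirectly. It is methoxy in place of methyl on an aromatic carbon, which is not the change at hand. Within the data shown here, no measurement yet shows what isopropyl in place of methyl does on that oxygen. Among the measured compounds shown here, since the one measured step of a 1.1-fold higher number from compound 1 to compound 2 (0.05 log units; within the scatter) stays within the scatter, no step beyond the scatter is expected for compound 3 in this assay and neither direction is favoured. The expected step is a 1.0-fold lower number from compound 2 to compound 3 (0.02 log units; within the scatter) and so remains small. For compound 3 the estimated value is 65000 nM with an expected range from 30000 nM to 130000 nM as the upper end.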

Compound 3, half-maximal inhibitory concentration: 56600 nM
Estimate against measurement, compound 3: 1.1-fold (0.06 log units) above; the measured number falls inside the stated range.
By their numbers in this assay, from the lowest: compounds 3, 1 and 2 (each within the scatter of the next).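

In this assay, going by these compounds alone, isopropyl in place of methyl on an oxygen on an aromatic ring gives a 1.2-fold lower number from compound 2 to compound 3 (0.08 log units; within the scatter) and so provides the first direct reading of a change on that oxygen, which stays within the scatter even though the group grows from 1 heavy atom to 3 heavy atoms. The remaining pair gives a 1.1-fold lower number from compound 1 to compound 3 (0.03 log units; within the scatter) and also stays within the scatter, so methyl, methoxy and isopropoxy at this place all leave the number level in this set of three compounds. Nothing measured here offers an explanation for this level behaviour.

Whether a longer chain on that oxygen, or a chain ending in an amine or a carboxylic acid, would move the number beyond the scatter stays open, as all the groups shown there are small and made of carbon only. On these data alone, the rest of the shared core is the same in all three compounds, so it also stays open whether this place would behave the same way if another part of the core carried a different group.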